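The source may report more compounds than this note shows. Statements on the series, on what has been measured and on what is new or still open speak of the compounds shown alone.

Of the compounds shown here, three have so far been measured in a functional assay on HeLa cells (Homo sapiens) for antiproliferative activity, read by MTT assay, with a stated time of 72 h; a higher number here means a weaker inhibitor, a lower number a stronger inhibitor. Compound 1 `COc1ccc(N2C(=O)COc3ccc(-c4cnc(OC)c(NS(=O)(=O)c5ccc(F)cc5)c4)cc32)cc1` gives 1220 nM in this assay, the lowest of the two plain numbers recorded. Compound 3 `O=C1COc2ccc(-c3cnc(Cl)c(NS(=O)(=O)c4ccc(F)cc4)c3)cc2N1C1CCCCC1` gives 14300 nM in this assay, a number that lies beyond the usual scatter above that of compound 1. Compound 2 `O=C1COc2ccc(-c3ccc(O)cc3)cc2N1` reached only (the limit of > 40000 nM in this assay, at which 1 of the 3 values shown sits), so the result > 40000 nM for compound 2 is a limit of the assay and not a number.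

Compound 4 `COc1ncc(-c2ccc3c(c2)N(c2ccc(Cl)cc2)C(=O)CO3)cc1NS(=O)(=O)c1ccc(F)cc1` has not yet been measured. It differs from compound 1 in a single place: chloro in place of methoxy on an aromatic carbon. Among the measured compounds shown here, no two measured compounds differ by only this change, so its size cannot be read from the data. A change of this kind is expected to move the number little, with no clear direction, staying within the usual scatter. Compound 4 is therefore estimated at 1200 nM in this assay, with a range from 450 nM to 3200 nM. The expected step is a 1.0-fold lower number from compound 1 to compound 4 (0.01 log units; within the scatter).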

Compound 4, half-maximal inhibitory concentration: 4830 nM
Beside the measured number, compound 4's estimate is 4.0-fold (0.60 log units) below it; measured number above the stated range.
By their numbers in this assay, from the lowest: compound 1; then compound 4; then compound 3. At a limit, above all of these: compound 2.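

Chloro in place of methoxy is the first change here that can be read on its own, and in this assay it gives a 4.0-fold higher number from compound 1 to compound 4 (0.60 log units; beyond the scatter). This place, para to a large group on the six-membered aromatic ring, therefore affects the number: although the step is modest, it lies beyond the scatter, and the 4-methoxyphenyl of compound 1 remains ahead of the 4-chlorophenyl of compound 4. Nothing measured here bears on why the number rises with this change.

Going by these compounds, it remains open whether another group at this place, such as an amine, a hydroxyl or an ethoxy group, would match compound 1 or give a lower number. One step on one core also cannot show whether the same change would act alike on a different core.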